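This account rests on a few compounds, and the source may have more. Where it says the series, first, only, none or still open, it means among the compounds named here.

Compound 1 `CCS(=O)(=O)Nc1ccc(NC(=O)c2ccc(Cl)cc2)cc1C`: 125000 nM
Compound 2 `CCS(=O)(=O)Nc1ccc(NC(=O)c2ccc(Cl)cc2)cc1OC`: > 250000 nM, a limit of the assay rather than a number
Compound 3 `CCS(=O)(=O)Nc1ccc(NC(=O)c2ccc(Cl)cc2)cc1Cl`: > 250000 nM, a limit of the assay rather than a number

In an ADME assay on HEK293 cells (Homo sapiens) for cytotoxicity, read by MTT assay, with a stated time of 48 h (a lower number here means a stronger inhibitor, a higher number a weaker inhibitor), compound 1 gives a readable number. Compound 3 gives only a limit there, and the limit of > 250000 nM in this assay, at which 2 of the 3 values shown sit, notes where it sits. The move from compound 1 to compound 3 was an at least 2.0-fold higher number from compound 1 to compound 3 (0.30 log units; that floor lies within the scatter), and from compound 1 to compound 2 it was an at least 2.0-fold higher number from compound 1 to compound 2 (0.30 log units; that floor lies within the scatter). Compound 4 `CCS(=O)(=O)Nc1ccc(NC(=O)c2ccc(Cl)cc2)cc1F` differs from compound 3 by fluoro in place of chloro on an aromatic carbon. For the measured compounds named here, no measured step swaps one halogen for another, so the change itself gives no read; the step from compound 3 is only expected to stay close to the limit, a number no higher from compound 3 to compound 4 (the limit leaves the size open). Compound 4 is therefore estimated at 250000 nM, within 100000 nM to 500000 nM.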

Compound 4, half-maximal inhibitory concentration: 53400 nM
Compound 4: the middle estimate sits 4.7-fold (0.67 log units) above what was measured; measured number below the stated range.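

In this assay this position, ortho to a (ethylsulfonyl)amino group, proves sensitive to the swap of one halogen for another: an at least 4.6-fold lower number from compound 3 to compound 4 (0.67 log units; beyond the scatter). Fluoro also stands apart from methoxy, with an at least 4.6-fold lower number from compound 2 to compound 4 (0.67 log units; beyond the scatter), and from methyl, with a 2.3-fold lower number from compound 1 to compound 4 (0.37 log units; beyond the scatter). All three steps lie beyond the scatter, so compound 4 is the strongest inhibitor of the four shown.

On these data alone, the full size of the steps from compound 2 and compound 3 stays open because both compounds gave only a limit: the limit of > 250000 nM in this assay, at which 2 of the 4 values shown sit. As far as these compounds go, whether a nitrile or an amine at this position would give a lower number also remains open.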